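The source may report more compounds than this note shows. Statements on the series, on what has been measured and on what is new or still open speak of the compounds shown alone.

Measured so far:
- Compound 1 `CC(C)OC(=O)C1=C(C(F)(F)F)NC(=O)NC1c1ccoc1`: 1% in an assay on HeLa cells for displacement of a labelled ligand from adenosine receptor A3 (Homo sapiens), read by radioligand binding, with a stated time of 180 min, tested at 1 uM; on this read-out lower numbers stand for less inhibition and higher numbers for more inhibition at the one concentration tested (going by the name of the read-out).
- Compound 2 `CCOC(=O)C1=C(C(F)(F)F)NC(=O)NC1c1ccsc1`: 3% in this assay.

Compound 2 and compound 1 lie within the usual scatter of each other in this assay, so neither stands apart; both show little inhibition at the single concentration tested. Among the measured compounds shown here, no step between measured compounds has been computed. Compound 3 `CCOC(=O)C1=C(C(F)(F)F)NC(=O)NC1c1ccoc1` is the next compound, differing from compound 2 by furan-3-yl in place of thiophen-3-yl on a saturated ring carbon. Compound 1 also carries furan-3-yl and gives 1%, so no step beyond the scatter is expected from compound 2 to compound 3 in this assay: the expected step is a number 1 percentage points lower from compound 2 to compound 3 (within the scatter). Compound 3 is estimated at 2%, range 0% to 12%.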

Compound 3, a percentage reported as inhibition, at one concentration (the size of the read-out at that concentration, not a potency): 1%
Compound 3: the middle estimate sits 1 percentage points above what was measured; measured number inside the range.
By their numbers in this assay, from the lowest: compounds 1, 3 and 2 (each within the scatter of the next).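

In this assay, among the compounds shown here, furan-3-yl in place of thiophen-3-yl on the saturated ring carbon gives a number 2 percentage points lower from compound 2 to compound 3 (within the scatter) and is the first direct reading of this exchange at this position. At the ester, hydrogen in place of methyl on the saturated chain carbon bound to an oxygen gives no change at the digits printed from compound 1 to compound 3 (within the scatter) and so adds a second change that stays within the scatter. No available evidence explains either step.

Still open, going by these compounds, is whether an amine or a carboxylic acid on the aromatic ring at this ring carbon, or a longer chain on the ester, would give a step beyond the scatter.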